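The source may hold more compounds than are shown below. What is called first, only, known or untested is meant among the compounds shown, and "the series" means these compounds.

Compound 2 `O=C(CC1c2ccccc2N=C(SCCCCCN2CCCC2)N1c1ccccc1)NCc1ccccc1` stands as the lower of the two measured numbers in an assay on cells for inhibition of Voltage-dependent T-type calcium channel subunit alpha-1H (Homo sapiens), read by patch clamp, tested at 10 uM; on this read-out lower numbers stand for less inhibition and higher numbers for more inhibition at the one concentration tested (going by the name of the read-out): compound 2 gives 61.6%, while compound 1 `O=C(CC1c2ccccc2N=C(SCCCCCN2CCCC2)N1c1ccc(-c2ccc(F)cc2)cc1)NCc1ccccc1` gives 97.5%. The single step shown, a number 35.9 percentage points lower from compound 1 to compound 2 (beyond the scatter), is large. Compound 3 `O=C(CC1c2ccccc2N=C(SCCCCCN2CCCC2)N1c1ccc(-c2ccccc2)cc1)NCc1ccccc1` reverses that change in kind, though without the fluorine: phenyl in place of hydrogen on an aromatic carbon. Among the measured compounds shown here, the measured step is the only one bearing on this change and points to a rise of roughly comparable size. For the measured compounds named here, no measured pair separates 4-fluorophenyl from phenyl; that part of the gap is uncertain, and the estimate is held slightly under the value of compound 1. Compound 3 is therefore expected to show a number 28.4 percentage points higher from compound 2 to compound 3 (beyond the scatter). The estimate for compound 3 in this assay is 90%, with a range of 74% to 99%.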

Compound 3, a percentage reported as inhibition, at one concentration (the size of the read-out at that concentration, not a potency): 73.1%
Compound 3: middle estimate off by 16.9 percentage points, on the high side, and the stated range ends above it.
By their numbers in this assay, from the lowest: compound 2; then compound 3; then compound 1.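

In this assay, the step of a number 11.5 percentage points higher from compound 2 to compound 3 (beyond the scatter) shows that phenyl at this place, para to a large group, gives a gain beyond the scatter, but only part of the gain that 4-fluorophenyl gives. The step of a number 24.4 percentage points lower from compound 1 to compound 3 (beyond the scatter) shows that the single fluoro also matters, and its step is the larger of the two, so the size of the gain depends on more than the added ring. Nothing at hand says why this one atom counts for so much.

Going by these compounds, it remains open whether chloro, methyl or methoxy in place of the fluoro of compound 1 would hold the higher number, or whether the gain is particular to fluoro. On these data alone, it is also open whether fluoro alone, in place of the added phenyl of compound 3, would give any gain over compound 2.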